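This account rests on a few compounds, and the source may have more. Where it says the series, first, only, none or still open, it means among the compounds named here.

Measured compounds:
- Compound 1 `O=C(O)[C@@H]1CCCN1C(=O)CN(c1nc(Cl)nc2[nH]cnc12)C1CC1`, 7.29%
- Compound 2 `CSCC[C@H](NC(=O)CN(c1nc(Cl)nc2[nH]cnc12)C1CC1)C(=O)OCc1ccccc1`, 17.6%
- Compound 3 `O=C(OCc1ccccc1)[C@@H]1CCCN1C(=O)CN(c1nc(Cl)nc2[nH]cnc12)C1CC1`, 31.1%

In a functional assay on the whole organism (Tail, strain ICR) with Mus musculus as the target, in the tail flick test, with a stated time of 150 min, at a dose of 25 umol/kg by the oral route (a higher number here means a stronger effect of the compound at the dose given, a lower number a weaker effect), compound 1 gives 7.29%, the lowest of the three numbers; compound 2 gives 17.6% and compound 3 gives 31.1%. Among the compounds with values here, the one step that can be read between two measured compounds is a number 23.8 percentage points higher from compound 1 to compound 3 (beyond the scatter), and it concerns the acid end of the molecule, not the ring.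

Compound 4 `C[C@@H](O)[C@H](NC(=O)CN(c1nc(Cl)nc2[nH]cnc12)C1CC1)C(=O)O` keeps the shared core and the free acid of compound 1 but differs in one place: (1-carboxy-2-hydroxypropyl)amino in place of 2-carboxypyrrolidin-1-yl on a carbonyl carbon. Within the data shown here, no measured pair shows this change, so no step bears on it directly. Compound 2 shows only that an open-chain amino acid can sit at that position and still give a low number, and compound 4 retains the free acid that in compound 1 goes with the lowest value. A small step is therefore expected, estimated as a number 2.7 percentage points higher from compound 1 to compound 4 (within the scatter). Compound 4 is expected to give about 10%, within a range from 0% to 25%.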

Compound 4, a percentage reported as activity, at one dose (the size of the read-out at that dose, not a potency): 24%
Estimate against measurement, compound 4: 14 percentage points below; the measured number falls inside the stated range.
By their numbers in this assay, from the lowest: compound 1; then compounds 2, 4 and 3 (each within the scatter of the next, the first and the last beyond it).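

In this assay, putting (1-carboxy-2-hydroxypropyl)amino in place of 2-carboxypyrrolidin-1-yl on a carbonyl carbon gives a number 16.7 percentage points higher from compound 1 to compound 4 (beyond the scatter), with the free acid still present. The earlier step, a number 23.8 percentage points higher from compound 1 to compound 3 (beyond the scatter), replaced the acid hydrogen with benzyl; this one shows that the number can also rise when the acid stays and the five-membered ring gives way to an open chain. Nothing here explains why the number rises.

The entering group differs from the one it replaces in both its ring and its hydroxyl, so a group such as (1-carboxyethyl)amino, which has no ring and no hydroxyl, would be needed to separate the two. From the compounds shown here alone, it also remains open whether a benzyl ester on compound 4 would raise the number as it does on compound 1.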